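A Pyridin-4-yl Arm on the Core of Compound 1

This account rests on a few compounds, and the source may have more. Where it says the series, first, only, none or still open, it means among the compounds named here.

Three measured compounds share one core and differ only in the aromatic group on the carbon with a double bond to nitrogen. Compound 1 `O=C(N/N=C/c1ccc(F)cc1)c1cccnc1Nc1cccc(C(F)(F)F)c1` carries a 4-fluorophenyl there, compound 2 `COc1ccc(/C=N/NC(=O)c2cccnc2Nc2cccc(C(F)(F)F)c2)c(OC)c1` a 2,4-dimethoxyphenyl, and compound 3 `CN(C)c1ccc(/C=N/NC(=O)c2cccnc2Nc2cccc(C(F)(F)F)c2)cc1` a 4-(dimethylamino)phenyl. In a functional assay on the whole organism (strain Wistar) for inhibition, with Rattus norvegicus as the target, read by paw edema, with a stated time of 30 min, at a dose of 10 mg/kg by the intraperitoneal route (a higher number here means more inhibition at the dose given (going by the name of the read-out), a lower number less inhibition), compound 1 gives 33.9%, the lowest of the three numbers. Compound 2 gives 37.8%, and the step of a number 3.9 percentage points higher from compound 1 to compound 2 (within the scatter) lies within the scatter. Compound 3 gives 61.3%; the steps of a number 27.4 percentage points higher from compound 1 to compound 3 (beyond the scatter) and a number 23.5 percentage points higher from compound 2 to compound 3 (beyond the scatter) both lie beyond it.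

Compound 4 `O=C(N/N=C/c1ccncc1)c1cccnc1Nc1cccc(C(F)(F)F)c1` has not yet been measured. It differs from compound 1 in one place: pyridin-4-yl in place of 4-fluorophenyl on a carbon with a double bond to nitrogen. Among the compounds with values here, no measured step exchanges the 4-fluorophenyl for a six-membered aromatic ring with a hetero atom, so the bearing of the three steps is indirect. The step of a number 3.9 percentage points higher from compound 1 to compound 2 (within the scatter) shows that one exchange of the aromatic group on this carbon left the number almost unchanged, while the step of a number 27.4 percentage points higher from compound 1 to compound 3 (beyond the scatter) shows that another raised it modestly. Compound 4 is therefore expected to show a step of a number 2.1 percentage points higher from compound 1 to compound 4 (within the scatter) that may not exceed the scatter. The estimate for compound 4 is 36%, with a range from 22% to 52%.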

Compound 4, a percentage reported as inhibition, in the whole organism at one dose (the size of the read-out at that dose, not a potency): 68.1%
Compound 4: the middle estimate sits 32.1 percentage points below what was measured; the measured number lies above the stated range.
By their numbers in this assay, from the lowest: compounds 1 and 2 (each within the scatter of the next); then compounds 3 and 4 (each within the scatter of the next).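

In this assay, within the data shown here, exchanging the aromatic group on this carbon can do more than the earlier compounds showed: the step of a number 34.2 percentage points higher from compound 1 to compound 4 (beyond the scatter) is large, as is the step of a number 30.3 percentage points higher from compound 2 to compound 4 (beyond the scatter), whereas the earlier steps to compound 3 were only modest. The step of a number 6.8 percentage points higher from compound 3 to compound 4 (within the scatter) places pyridin-4-yl level with the 4-(dimethylamino)phenyl of compound 3, so a high number at this position no longer rests on one group, and it now also appears with a six-membered aromatic ring with a hetero atom. Nothing at hand accounts for the rise seen with this change.

A plain phenyl on this carbon would separate the entry of the ring nitrogen from the departure of the fluoro, while pyridin-3-yl and pyridin-2-yl would show whether the place of that nitrogen in the ring matters. On these data alone, it also remains open whether compound 3 and compound 4 would stay level at other doses or at later times after dosing.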